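Moving the methoxy group on a weakly cytotoxic compound

The compounds below may be only part of what the source reports. "The series", "measured", "known", "first", "only" and "open" are said of these compounds alone.

In a functional assay on ECa-109 cells (Homo sapiens) for cytotoxicity, read by MTT assay, with a stated time of 72 h (on this read-out higher numbers stand for weaker inhibition and lower numbers for stronger inhibition), compound 1 (`O=C1C(=Cc2ccc(Br)cc2)C(=O)N(c2ccc(Cl)cc2)N1c1ccc(Cl)cc1`) gives 12300 nM as its measured value. Compound 2 (`COc1ccc(C=C2C(=O)N(c3ccc(Cl)cc3)N(c3ccc(Cl)cc3)C2=O)cc1`) shows > 128000 nM as a limit of the assay and not a number. Compound 3 (`COc1ccccc1C=C1C(=O)N(c2ccc(Cl)cc2)N(c2ccc(Cl)cc2)C1=O`) carries 2-methoxyphenyl in place of 4-methoxyphenyl on a double-bonded chain carbon bound to a double-bonded ring carbon. Among the measured compounds shown here, the only measured step that bears on this is large (an at least 10-fold higher number from compound 1 to compound 2 (1.01 log units; beyond the scatter)) but concerns a different exchange, methoxy in place of bromo on an aromatic carbon. A moderate step to a lower number in this assay is therefore expected, though not a firm one. Compound 3 is estimated at 70000 nM with an expected range of 18000 nM to 220000 nM in this assay. The expected change is an at least 1.8-fold lower number from compound 2 to compound 3 (0.26 log units; that floor lies within the scatter) on this estimate.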

Compound 3, half-maximal inhibitory concentration: 30400 nM
Estimate against measurement, compound 3: 2.3-fold (0.36 log units) above; the range from low to high includes it.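

Exchanging 4-methoxyphenyl for 2-methoxyphenyl on a double-bonded chain carbon bound to a double-bonded ring carbon gives an at least 4.2-fold lower number from compound 2 to compound 3 (0.62 log units; beyond the scatter) in this assay even though the atoms stay the same. Methoxy is thus compatible with a measured value here, yet the exchange for 4-bromophenyl still gives a 2.5-fold higher number from compound 1 to compound 3 (0.39 log units; beyond the scatter) in this comparison. Compound 2 has a limit of the assay and not a number, so the first step has only a floor: the limit of > 128000 nM in this assay, at which 1 of the 3 values shown sits.

Left open is how an amine or a hydroxy group would read in place of the methoxy.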